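A thiophen-2-yl swap at the assay limit

This account rests on a few compounds, and the source may have more. Where it says the series, first, only, none or still open, it means among the compounds named here.

Compound 1 `COc1cc(-c2c(C)nc3c(N4CC[C@@H](NC(C)=O)C4)cc(C)nn23)ccc1F`: > 95% (a limit)
Compound 2 `COc1ccc(-c2c(C)nc3c(N4CC[C@@H](NC(C)=O)C4)cc(C)nn23)cc1F`: > 95% (a limit)

In an ADME assay on microsomes from liver (Homo sapiens) for metabolic stability, read by LC-MS, with NADPH named in the record, with a stated time of 60 min, tested at 1 uM, in the absence of a further agent (a higher number here means that more of the compound is left, a lower number that less of the compound is left), compound 2 gives > 95%, a limit and not a number. The measurements so far show (the limit of > 95% in this assay, at which 2 of the 2 values shown sit). Going by the values given here, the only measured step, a step that the two limits leave unreadable from compound 1 to compound 2, has no readable size and so offers no guide. Compound 3 `CC(=O)N[C@@H]1CCN(c2cc(C)nn3c(-c4cccs4)c(C)nc23)C1` differs from compound 2 by thiophen-2-yl in place of 3-fluoro-4-methoxyphenyl on an aromatic carbon, with thiophen-2-yl in place of 3-fluoro-4-methoxyphenyl on an aromatic carbon. With compound 2 at the limit of > 95%, only a downward step could be read. The estimated step is a number at least 7 percentage points lower from compound 2 to compound 3 (that floor lies within the scatter), expected to be modest and downward if it shows at all. Compound 3 is expected at 88%, within an estimated range of 65% to 100%.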

Compound 3, percent of the compound remaining: > 95%
Compound 3: only a limit was reported; the forecaster's own chance of this, stated with the estimate: 45%; at least 7 percentage points between middle value and limit.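

In this assay, going by these compounds alone, compound 3 also gives a limit and not a number, so no step among compound 1, compound 2 and compound 3 can be read. These compounds leave open whether thiophen-2-yl in place of 3-fluoro-4-methoxyphenyl changes the percent of compound remaining at all.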